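Swapping a fluoropyridine for a methylpyridine on the piperazine

The compounds below may be only part of what the source reports. "The series", "measured", "known", "first", "only" and "open" are said of these compounds alone.

Compound 1 `Fc1cccnc1N1CCN(Cc2nc3ccccc3[nH]2)CC1` gives 24 nM in an assay on HEK293 cells with D(4) dopamine receptor (Homo sapiens) as the target, read by FLIPR (a higher number here means that more compound is needed for the effect, a lower number that less compound is needed), the lowest of the three numbers measured. Compound 2 `CCOc1ccccc1N1CCN(Cc2nc3ccccc3[nH]2)CC1` gives 25 nM, a number indistinguishable from that of compound 1 within the usual scatter. Compound 3 `CSc1ccccc1N1CCN(Cc2nc3ccccc3[nH]2)CC1` gives 86 nM, and the step of a 3.6-fold higher number from compound 1 to compound 3 (0.55 log units; beyond the scatter) is a modest one. Compound 4 `Cc1cccc(N2CCN(Cc3nc4ccccc4[nH]3)CC2)n1` differs from compound 1 in one place: 6-methylpyridin-2-yl in place of 3-fluoropyridin-2-yl on an amine nitrogen in a ring. Within the data shown here, the only measured step at this position, a 3.6-fold higher number from compound 1 to compound 3 (0.55 log units; beyond the scatter), exchanged the whole ring for a different aromatic ring, and a 3.4-fold higher number from compound 2 to compound 3 (0.54 log units; beyond the scatter) varied a substituent elsewhere; neither tests a methyl on a pyridine here, so no step beyond the scatter is expected. Compound 4 is therefore estimated at 30 nM, between 10 nM and 90 nM, a change of a 1.3-fold higher number from compound 1 to compound 4 (0.10 log units; within the scatter).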

Compound 4, half-maximal effective concentration: 36.2 nM
Compound 4: the middle estimate sits 1.2-fold (0.08 log units) below what was measured, and the stated range covers the measured number.
By their numbers in this assay, from the lowest: compounds 1, 2 and 4 (each within the scatter of the next); then compound 3.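

On the amine nitrogen in a ring, two differently substituted pyridines prove interchangeable in this assay: 6-methylpyridin-2-yl replaces 3-fluoropyridin-2-yl with a step within the scatter (a 1.5-fold higher number from compound 1 to compound 4 (0.18 log units; within the scatter)). Replacing 2-(methylsulfanyl)phenyl with 6-methylpyridin-2-yl gives a modest step down (a 2.4-fold lower number from compound 3 to compound 4 (0.38 log units; beyond the scatter)), but this is no general pyridine advantage, as the ethoxy-bearing phenyl ring of compound 2 also has a low number. Nothing available explains these steps. On these data alone, what remains open is how a pyridine bearing an amine, a carboxylic acid or a longer chain would behave at this position.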